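Ring size on the amide: cycloheptyl to cyclopropyl

A few compounds are considered here, and "the series" means these few. Any claim that something is new, unique, unknown or untested is made for them only; others in the source may bear on it.

Measured in a functional assay on BXPC-3 cells (Homo sapiens) for cytotoxicity, read by fluorescence, with a stated time of 48 h; on this read-out higher numbers stand for an effect only at larger amounts of compound and lower numbers for an effect already at smaller amounts:
- compound 1 `CC(C)=CCC/C(C)=C/CC/C(C)=C/CSC[C@H](NC(=O)CCCCCN1CCCC1)C(=O)NC1CCCCC1`: 12700 nM
- compound 2 `CC(C)=CCC/C(C)=C/CC/C(C)=C/CSC[C@H](NC(=O)CCCCCN1CCCC1)C(=O)NC1CCCC1`: 6800 nM
- compound 3 `CC(C)=CCC/C(C)=C/CC/C(C)=C/CSC[C@H](NC(=O)CCCCCN1CCCC1)C(=O)NC1CCCCCC1`: 5800 nM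

Compound 3 gives 5800 nM. Two steps place it: a 1.2-fold lower number from compound 2 to compound 3 (0.07 log units; within the scatter), and a 2.2-fold lower number from compound 1 to compound 3 (0.34 log units; beyond the scatter). It therefore cannot be separated from compound 2 and stands clear of compound 1 only.

Compound 4 `CC(C)=CCC/C(C)=C/CC/C(C)=C/CSC[C@H](NC(=O)CCCCCN1CCCC1)C(=O)NC1CC1` carries cyclopropyl in place of cycloheptyl on an amide-type nitrogen. The bearing evidence is the three ring swaps at this same place, which also include a 1.9-fold lower number from compound 1 to compound 2 (0.27 log units; within the scatter). All are small, and they show no steady trend with ring size, as compound 1 goes against any such trend. No ring as small as cyclopropyl has been measured. A modest step is expected in this assay, leaning towards a higher number, since compound 3 sits at the low end of a span whose high end is compound 1 with 12700 nM, though the direction is uncertain. The expected step is a 1.9-fold higher number from compound 3 to compound 4 (0.28 log units; within the scatter). The estimate for compound 4 is 11000 nM, with an expected range of 4500 nM to 28000 nM.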

Compound 4, half-maximal effective concentration: > 20000 nM
Compound 4 gave a limit, no number; the forecaster's own chance of this, stated with the estimate: 10%; middle value at least 1.8-fold (0.25 log units) from the limit.
By their numbers in this assay, from the lowest: compounds 3, 2 and 1 (each within the scatter of the next, the first and the last beyond it). At a limit, above all of these: compound 4.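

Compound 4 gives > 20000 nM in this assay, a limit and not a number, so each step to it is only a floor: the limit of > 20000 nM in this assay, at which 1 of the 4 values shown sits. With cyclopropyl on the amide-type nitrogen, an at least 3.4-fold higher number from compound 3 to compound 4 (0.53 log units; beyond the scatter) and an at least 2.9-fold higher number from compound 2 to compound 4 (0.46 log units; beyond the scatter) show that the smallest ring shown separates from both cycloheptyl and cyclopentyl, so this position does respond to the ring. The third step, an at least 1.5-fold higher number from compound 1 to compound 4 (0.19 log units; that floor lies within the scatter), does not separate cyclopropyl from cyclohexyl, and compound 1 still goes against any steady trend with ring size.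

Going by these compounds, the true number for compound 4 remains unknown, and so does the full size of its steps. Also open are where cyclobutyl would fall among these rings, and whether an open-chain group such as isopropyl or a ring holding an oxygen, such as tetrahydropyranyl, would be tolerated at this nitrogen.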